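The compounds below may be only part of what the source reports. "The series", "measured", "known", "first", "only" and "open" are said of these compounds alone.

Compound 1, `Nc1nnc(-c2ccccc2OCc2ccccc2)o1`, gives 85.2 mg/kg in a functional assay on the whole organism with Mus musculus as the target; a lower number here means that less compound is needed, a higher number that more compound is needed for the effect.
Compound 2, `CSc1nnc(-c2ccccc2OCc2ccccc2)o1`, gives 91.2 mg/kg in this assay.

Compound 2 and compound 1 differ by a 1.1-fold higher number from compound 1 to compound 2 (0.03 log units; within the scatter), a step that stays within the scatter, so on the two numbers at hand compound 2 does not stand apart from compound 1. The new compound, compound 3, `CCSc1nnc(-c2ccccc2OCc2ccccc2)o1`, differs from compound 2 by methyl in place of hydrogen on a saturated chain carbon bound to a sulfur. Among the measured compounds shown here, only one measured step exists, and it concerns a different place: swapping the group on the aromatic carbon, not lengthening the chain on the sulfur. That step was small. For the measured compounds named here, no measured pair tests what adding a methyl to this chain does, so the expectation rests on the general quietness seen so far. Compound 3 is therefore expected to show a step of a 1.0-fold lower number from compound 2 to compound 3 (0.01 log units; within the scatter) from compound 2, nothing beyond the scatter. The estimate for compound 3 is 90 mg/kg, with a likely range from 50 mg/kg to 170 mg/kg.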

Compound 3, dose for half-maximal effect: > 100 mg/kg
Compound 3 ended at the assay's limit; the forecaster's own chance of this, stated with the estimate: 10%; middle value at least 1.1-fold (0.04 log units) away from the limit.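

In this assay compound 3 gives > 100 mg/kg and that is a limit of the assay, not a number. Methyl in place of hydrogen on the saturated chain carbon bound to the sulfur, the first change tested at this place, gives one step (an at least 1.0-fold higher number from compound 2 to compound 3 (0.04 log units; that floor lies within the scatter)), and ethylsulfanyl in place of amino on the aromatic carbon gives another (an at least 1.1-fold higher number from compound 1 to compound 3 (0.06 log units; that floor lies within the scatter)). Both are only floors lying within the scatter, so neither change can be said to move the number, yet a much larger true step is not excluded either.

Going by these compounds, how far compound 3 really lies past the limit stays unknown, and with it the true size of the effect of the added methyl. Also open, on these data alone, is whether a longer chain, a carboxylic acid or an amine in place of the ethyl would bring the number down.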